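A Longer Sulfonyl Chain on the Shared Core

The source may hold more compounds than are shown below. What is called first, only, known or untested is meant among the compounds shown, and "the series" means these compounds.

Of the compounds shown here, two have been measured so far. Compound 1, `CS(=O)(=O)N1CCC2(CC1)OOC1(CCCC1)OO2`, carries a methylsulfonyl group on the shared core. In a functional assay on Huh-7 cells (Homo sapiens) for cytotoxicity, read by MTT assay, with a stated time of 72 h (on this read-out higher numbers stand for lower toxicity in this test and lower numbers for higher toxicity in this test), compound 1 reaches only the limit of the test, > 100 ug/mL. Compound 2, `CCCS(=O)(=O)N1CCC2(CC1)OOC1(CCCCCC1)OO2`, differs from it in both the sulfonyl chain and the core. In this assay compound 2 likewise reaches only the limit, > 100 ug/mL. Within the data shown here, both results therefore rest at the same limit (the limit of > 100 ug/mL in this assay, at which 2 of the 2 values shown sit), so no measured step can be put into numbers, and compound 1 stands at that limit as far as the numbers go.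

Compound 3, `CCCCS(=O)(=O)N1CCC2(CC1)OOC1(CCCC1)OO2`, has not yet been measured. It differs from compound 1 in one place: propyl in place of hydrogen on a saturated chain carbon bound to a sulfonyl sulfur. Read one bond further out, this is methylsulfonyl becoming butylsulfonyl. Among the measured compounds shown here, with no measured step for such a change, the step that the limit leaves unreadable from compound 1 to compound 3 is expected to show no change beyond the scatter. Compound 3 is accordingly expected to give 150 ug/mL, with a range from 80 ug/mL to 400 ug/mL, most likely again only as a limit.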

Compound 3, half-maximal cytotoxic concentration: > 100 ug/mL
Compound 3: a limit, no number; the forecaster's own chance of this, stated with the estimate: 85%; the middle value is on the limit's open side.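

In this assay, among these compounds, compound 3 also gives only a limit, so no step from compound 1 to compound 3 can be read: the limit of > 100 ug/mL in this assay, at which 3 of the 3 values shown sit. The compounds shown leave open whether changing the sulfonyl chain alters the half-maximal cytotoxic concentration at all.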